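The source may report more compounds than this note shows. Statements on the series, on what has been measured and on what is new or still open speak of the compounds shown alone.

Measured in a functional assay on HCT-116 cells (Homo sapiens) for antiproliferative activity, read by MTT assay, with a stated time of 24 h; a higher number here means a weaker inhibitor, a lower number a stronger inhibitor:
- Compound 1 `COc1cccc(/C=C/C(=O)c2ccc(OC)c3c2OC(C)(C)C=C3)c1`: > 10000 nM (a limit)
- Compound 2 `COc1ccc(C(=O)/C=C/c2cccc(F)c2)c2c1C=CC(C)(C)O2`: > 10000 nM (a limit)
- Compound 3 `COc1ccc(C(=O)/C=C/c2cccc([N+](=O)[O-])c2)c2c1C=CC(C)(C)O2`: 8050 nM

Compound 3 is the only one of the three with a true number. All else here is the limit of > 10000 nM in this assay, at which 2 of the 3 values shown sit.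

Compound 4 `COc1ccc(C(=O)/C=C/c2ccc(Cl)cc2)c2c1C=CC(C)(C)O2` differs from compound 3 in one place: 4-chlorophenyl in place of 3-nitrophenyl on a double-bonded chain carbon bound to a double-bonded chain carbon.

Going by the values given here, three measured steps bear on this change, each a swap of one group on an aromatic carbon: an at least 1.2-fold lower number from compound 1 to compound 3 (0.09 log units; that floor lies within the scatter), an at least 1.2-fold lower number from compound 2 to compound 3 (0.09 log units; that floor lies within the scatter) and a step that the two limits leave unreadable from compound 1 to compound 2. The first two give only floors within the scatter, and the third cannot be sized. No step beyond the scatter is therefore expected, and the estimated step is a 1.1-fold higher number from compound 3 to compound 4 (0.05 log units; within the scatter). For compound 4 the expected value is 9000 nM, with an estimated range from 3500 nM to 20000 nM.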

Compound 4, half-maximal inhibitory concentration: > 10000 nM
Compound 4 was reported as a limit (the forecaster's own chance of this, stated with the estimate: 45%); middle value at least 1.1-fold (0.04 log units) from the limit.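

In this assay compound 4 gives > 10000 nM as a limit. The change to 4-chlorophenyl gives an at least 1.2-fold higher number from compound 3 to compound 4 (0.09 log units; that floor lies within the scatter) and so shows no readable change at this position, while the steps from compound 1 and compound 2 cannot be read. Going by these compounds alone, compound 3 remains the only true number, and a second substituted ring now joins the compounds at the same limit: the limit of > 10000 nM in this assay, at which 3 of the 4 values shown sit.

From the compounds shown here alone, whether an amine or a carboxylic acid on this phenyl ring would give a number well clear of the limit remains open.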